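The compounds below may be only part of what the source reports. "The series", "measured", "known", "first", "only" and "open" are said of these compounds alone.

Series notes. In a functional assay on A-375 cells (Homo sapiens) for antiproliferative activity, read by CCK-8 assay, with a stated time of 72 h, tested at 8 uM (on this read-out higher numbers stand for a stronger effect at the one concentration tested and lower numbers for a weaker effect), compound 1 `Nc1ccccc1NC(=O)c1ccc(CSC(=S)N2CCN(c3ccccc3)CC2)cc1` gives 88.6%. In this assay compound 2 `CN(C(=S)SCc1ccc(C(=O)Nc2ccccc2N)cc1)c1cccnc1` gives 87.7%, and compound 3 `Nc1ccccc1NC(=O)c1ccc(CSC(=S)N2CCCc3ccccc32)cc1` gives 81.5%. Compound 1 carries the highest of the three numbers, but its gaps to compound 2 and to compound 3 are both within the scatter, so no order among the three can be drawn. For the measured compounds named here, the one step between close neighbours, a number 6.2 percentage points lower from compound 2 to compound 3 (within the scatter), exchanges the group on the thiocarbonyl carbon and stays within the scatter.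

Compound 4 `Nc1ccccc1NC(=O)c1ccc(CSC(=S)N2CCN(C3CCCCC3)CC2)cc1` differs from compound 1 by cyclohexyl in place of phenyl on an amine nitrogen in a ring. Going by the values given here, no measured step touches this position; the only step at hand alters a different part of the shared core and lies within the scatter itself. All three measured compounds sit in a narrow band in this assay, so no step beyond the scatter is expected from this change. Compound 4 is therefore estimated at 85%, with a range of 70% to 95%. The expected change is a number 3.6 percentage points lower from compound 1 to compound 4 (within the scatter), nothing beyond the scatter.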

Compound 4, a percentage reported as inhibition, at one concentration (the size of the read-out at that concentration, not a potency): 89.9%
Beside the measured number, compound 4's estimate is 4.9 percentage points below it, and the stated range covers the measured number.
By their numbers in this assay, from the lowest: compounds 3, 2, 1 and 4 (each within the scatter of the next).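

In this assay, the position on the amine nitrogen in the ring now has a measured step of its own, and the step of a number 1.3 percentage points higher from compound 1 to compound 4 (within the scatter) shows that this position tolerates the exchange on this read-out. Phenyl and cyclohexyl differ here in whether the six-membered ring of carbon is aromatic, and that difference leaves compound 1 and compound 4 within the scatter of each other at the one concentration tested. Nothing at hand offers an explanation for this result.

The compounds shown leave open whether a methyl group, a longer alkyl chain, or a ring carrying a carboxylic acid or an amine would stay in the same band at this position. A read-out at one concentration also leaves open whether compound 1 and compound 4 differ in potency.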